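Bromothiophene in place of methylpyrazole: expected cytotoxicity

The source may hold more compounds than are shown below. What is called first, only, known or untested is meant among the compounds shown, and "the series" means these compounds.

Measured compounds:
compound 1 `C[C@H]1[C@H](NCc2sccc2C2CCCCC2)C[C@H]2C[C@@H]1C2(C)C` 1560 nM
compound 2 `C[C@H]1[C@H](NCc2ccoc2)C[C@H]2C[C@@H]1C2(C)C` > 100000 nM
compound 3 `Cc1n[nH]cc1CN[C@@H]1C[C@H]2C[C@@H]([C@H]1C)C2(C)C` > 100000 nM

In an ADME assay on MDCK cells (Canis lupus familiaris) for cytotoxicity, read by microscopy, with a stated time of 48 h (on this read-out higher numbers stand for lower toxicity in this test and lower numbers for higher toxicity in this test), compound 1 gives 1560 nM. Compound 2 gives > 100000 nM, which is a limit of the assay and not a number. Compound 3 also gives > 100000 nM, again only a limit. Compound 3 therefore stands at the limit of > 100000 nM in this assay, at which 2 of the 3 values shown sit, and the step that the two limits leave unreadable from compound 2 to compound 3 cannot be sized. Compound 4 `C[C@H]1[C@H](NCc2sccc2Br)C[C@H]2C[C@@H]1C2(C)C` differs from compound 3 by 3-bromothiophen-2-yl in place of 3-methyl-1H-pyrazol-4-yl on a saturated chain carbon bound to an amine nitrogen. Among the compounds with values here, no measured step matches this change; compound 1 carries a thiophene and shows a measurable value, while compound 3 does not. The estimated step of an at least 3.3-fold lower number from compound 3 to compound 4 (0.52 log units; beyond the scatter) is expected to bring compound 4 off the limit, with compound 4 estimated at 30000 nM (range 5000 nM to 100000 nM).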

Compound 4, minimum cytotoxic concentration: 50000 nM
Beside the measured number, compound 4's estimate is 1.7-fold (0.22 log units) below it, and the stated range covers the measured number.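

In this assay, 3-bromothiophen-2-yl on a saturated chain carbon bound to an amine nitrogen gives a readable number, which furan-3-yl and 3-methyl-1H-pyrazol-4-yl did not: the limit of > 100000 nM in this assay, at which 2 of the 4 values shown sit. Against those two limits, the result reads as an at least 2.0-fold lower number from compound 3 to compound 4 (0.30 log units; that floor lies within the scatter) and as an at least 2.0-fold lower number from compound 2 to compound 4 (0.30 log units; that floor lies within the scatter), so only a floor is known for either gap. On the thiophene itself, bromo in place of cyclohexyl gives a large shift: a 32-fold higher number from compound 1 to compound 4 (1.51 log units; beyond the scatter). The compounds shown leave open how much of this belongs to the thiophene and how much to its bromo group, and where a thiophene carrying an amine or a carboxylic acid would fall.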